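Stereochemistry at the chain carbinol and alpha-1 binding

This account rests on a few compounds, and the source may have more. Where it says the series, first, only, none or still open, it means among the compounds named here.

Measured compounds:
compound 1 `COc1ccccc1OCCNC[C@@H](O)COc1c(OC)ccc2[nH]ccc12` gives 45.8 nM
compound 2 `COc1ccccc1OCCNCC(O)COc1ccc(OC)c2[nH]ccc12` gives 75.8 nM
compound 3 `COc1ccccc1OCCNC[C@H](O)COc1ccc(OC)c2[nH]ccc12` gives 169 nM

In an assay on membranes from Cerebral cortex (strain Wistar) for displacement of a labelled ligand from Adrenergic receptor alpha-1 (Rattus norvegicus), read by scintillation counting (on this read-out lower numbers stand for stronger inhibition and higher numbers for weaker inhibition), compound 3 stands highest of the three numbers; its nearest neighbour is compound 2, and compound 1 lies furthest from it. The step from compound 3 to compound 4 `COc1ccccc1OCCNC[C@@H](O)COc1ccc(OC)c2[nH]ccc12` is the two compounds have the same atoms and bonds and differ only in configuration as drawn: 1 of 1 stereo elements differ; a stereocentre at a saturated chain carbon is drawn S in compound 3 and R in compound 4. Among the compounds with values here, the one measured step that bears on this is a 2.2-fold higher number from compound 2 to compound 3 (0.35 log units; beyond the scatter), and the fact that sets the two apart is the fact that one of compounds 2 and 3 is drawn with a defined configuration and the other without, at the place where they differ: compound 2 is drawn without configuration at that carbon, compound 3 with the S configuration. Within the data shown here, since compound 3 gave a higher number than the undefined compound 2, the other configuration, which compound 4 carries, is expected to give a lower number than compound 3 in this assay, and a step at least as large as the one from compound 2 to compound 3 is anticipated, in the opposite direction; the step of a 3.4-fold lower number from compound 3 to compound 4 (0.53 log units; beyond the scatter) is the expected size. Compound 4 is therefore estimated at 50 nM, with a range from 25 nM to 100 nM.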

Compound 4, inhibition constant: 60.9 nM
The estimate for compound 4 lay 1.2-fold (0.09 log units) below the measured number; the measured number falls inside the stated range.
By their numbers in this assay, from the lowest: compounds 1, 4 and 2 (each within the scatter of the next); then compound 3.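

In this assay, both drawn configurations of the chain carbinol now stand on the same core, and the configuration matters, with a 2.8-fold lower number from compound 3 to compound 4 (0.44 log units; beyond the scatter). Compound 3 had shown only that the S form gives a higher number than the undefined compound 2; this result shows that the R form accounts for the lower number, and the comparison isolates this one carbon: the fact that compounds 3 and 4 differ only in the configuration as drawn The R form cannot be told apart from the undefined material, with a 1.2-fold lower number from compound 2 to compound 4 (0.10 log units; within the scatter): the fact that one of compounds 2 and 4 is drawn with a defined configuration and the other without, at the place where they differ

The compounds shown leave open whether the same difference between S and R holds on the core of compound 1, for which one configuration stands here. They also leave open how this position responds when an amine or a methoxy group takes the place of the hydroxyl.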